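Swapping Cyano for Chloro at the Assay Limit

This account rests on a few compounds, and the source may have more. Where it says the series, first, only, none or still open, it means among the compounds named here.

Compound 1 `C(=C/c1nc2ccccn2c1Sc1ccccc1)\c1ccccc1`: > 100000 nM (a limit)
Compound 2 `CSc1ccc(-c2nc3ccccn3c2Sc2ccccc2)cc1`: > 100000 nM (a limit)
Compound 3 `N#Cc1ccc(-c2nc3ccccn3c2Sc2ccccc2)cc1`: > 100000 nM (a limit)

In an ADME assay on HEK293 cells (Homo sapiens) for inhibition, read by MTT assay, with a stated time of 48 h (on this read-out lower numbers stand for stronger inhibition and higher numbers for weaker inhibition), compound 3 reads > 100000 nM, which is a limit and not a number. All three measured compounds share one reading: the limit of > 100000 nM in this assay, at which 3 of the 3 values shown sit. So none of them has an exact value to start from.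

Compound 4 `Clc1ccc(-c2nc3ccccn3c2Sc2ccccc2)cc1` differs from compound 3 in one place, with chloro in place of cyano on an aromatic carbon, para to a large group: chloro in place of cyano on an aromatic carbon.

The closest measured change swaps one group for another at this same place: a step that the two limits leave unreadable from compound 2 to compound 3. The two changes that replace the 2-phenylethenyl group, a step that the two limits leave unreadable from compound 1 to compound 2 and a step that the two limits leave unreadable from compound 1 to compound 3, give no size either. Going by the values given here, no measured size or direction therefore carries over to the new swap, and the only guide is the shared limit.

The estimated change in this assay is a number no higher from compound 3 to compound 4 (the limit leaves the size open). For compound 4 the expected value is 100000 nM, with an estimated range from 50000 nM to 200000 nM.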

Compound 4, half-maximal inhibitory concentration: > 100000 nM
Compound 4: a limit, no number (the forecaster's own chance of this, stated with the estimate: 85%); the middle value sits exactly at the limit.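

Compound 4 reads as a limit and not a number in this assay, so no step between compound 1, compound 2, compound 3 and compound 4 can be read: the limit of > 100000 nM in this assay, at which 4 of the 4 values shown sit.

The compounds shown leave open how strongly, if at all, any of the four inhibits in this assay, and whether their groups differ in effect.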